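This account rests on a few compounds, and the source may have more. Where it says the series, first, only, none or still open, it means among the compounds named here.

Measured so far in a functional assay on U-87MG ATCC cells (Homo sapiens) for inhibition; on this read-out higher numbers stand for weaker inhibition and lower numbers for stronger inhibition:
Compound 1 `COc1cc(/C=C/C(=O)c2cccc(NC(=O)c3cccs3)c2)ccc1O` gives 14.7 ug/mL
Compound 2 `COc1cc(/C=C/C(=O)c2cccc(NC(=O)c3cc(Cl)cc(Cl)c3)c2)ccc1O` gives > 50 ug/mL
Compound 3 `COc1cc(/C=C/C(=O)c2cccc(NC(=O)c3ccco3)c2)ccc1O` gives 6.65 ug/mL

The entry for compound 2 (> 50 ug/mL) is a limit in this assay and not a number. Compound 3 has the lowest value of the set, and the nearest value is that of compound 1 (14.7 ug/mL). All three measured steps exchange the group on the carbonyl carbon. One is modest (a 2.2-fold lower number from compound 1 to compound 3 (0.34 log units; beyond the scatter)). The other two are at least modest (an at least 3.4-fold higher number from compound 1 to compound 2 (0.53 log units; beyond the scatter)) and (an at least 7.5-fold lower number from compound 2 to compound 3 (0.87 log units; beyond the scatter)).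

Compound 4 (`COc1cc(/C=C/C(=O)c2cccc(N)c2)ccc1O`) loses that group altogether (hydrogen in place of (furan-2-yl)carbonyl on a nitrogen on an aromatic ring). This puts hydrogen in place of (furan-2-yl)carbonyl on a nitrogen on an aromatic ring, so that ((furan-2-yl)carbonyl)amino becomes amino. Among the measured compounds shown here, no measured step removes the group, so these steps bear on the change only indirectly. They do show that the number moves with the group on the carbonyl carbon. A modest step towards a higher number is therefore expected, since compound 3 (6.65 ug/mL) already has the lowest value, though the direction is not secure. The estimated change is (a 2.3-fold higher number from compound 3 to compound 4 (0.35 log units; beyond the scatter)). Compound 4 is expected at (15 ug/mL), with an estimated range from (5 ug/mL) to (45 ug/mL).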

Compound 4, half-maximal inhibitory concentration: 7.71 ug/mL
Beside the measured number, compound 4's estimate is 1.9-fold (0.29 log units) above it; low and high end bracket the measured number.
By their numbers in this assay, from the lowest: compounds 3, 4 and 1 (each within the scatter of the next, the first and the last beyond it). At a limit, above all of these: compound 2.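

Taking the (furan-2-yl)carbonyl off the nitrogen on an aromatic ring, so that ((furan-2-yl)carbonyl)amino becomes amino, leaves the number in this assay within the scatter (a 1.2-fold higher number from compound 3 to compound 4 (0.06 log units; within the scatter)), so on this evidence the furan amide offers no measurable gain over the free amino group. The thiophene amide reads the same way, since removing (thiophen-2-yl)carbonyl also stays within the scatter (a 1.9-fold lower number from compound 1 to compound 4 (0.28 log units; within the scatter)), although the two amides remain apart from each other. Only the (3,5-dichlorophenyl)carbonyl group separates clearly from the free amino group (an at least 6.4-fold lower number from compound 2 to compound 4 (0.81 log units; beyond the scatter)), so at this position one acyl group of the three goes with weaker inhibition, and the true size of that step stays unknown, as the entry for compound 2 is a limit and not a number: the limit of > 50 ug/mL in this assay, at which 1 of the 4 values shown sits.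

As far as these compounds go, it remains open whether a plain benzoyl or an acetyl group on this nitrogen would stay level with the free amino group or fall away as the dichlorophenyl amide does, and so whether the two chlorine atoms matter. From the compounds shown here alone, it is equally open whether the amino group itself contributes, which a hydroxyl group or a bare hydrogen in its place would test.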